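The source may hold more compounds than are shown below. What is called first, only, known or untested is meant among the compounds shown, and "the series" means these compounds.

Compound 3, `C=CCn1c(=O)/c(=C\c2ccccc2F)[nH]c(=O)/c1=C\c1ccccc1OC`, holds the second highest of the three numbers in a functional assay on BGC-823 cells (Homo sapiens) for cytotoxicity, read by CCK-8 assay, with a stated time of 72 h; on this read-out higher numbers stand for weaker inhibition and lower numbers for stronger inhibition: compound 3 gives 18900 nM, nearest to compound 1, `C=CCn1c(=O)/c(=C\c2cccc(C)c2)[nH]c(=O)/c1=C\c1ccccc1OC`, which in this assay gives 20400 nM, and far from compound 2, `COc1ccccc1/C=c1\c(=O)[nH]/c(=C/c2cccc(Cl)c2Cl)c(=O)n1C`, which gives 300 nM. Going by the values given here, the one measured step at this position is a 1.1-fold lower number from compound 1 to compound 3 (0.03 log units; within the scatter), so one aryl swap there left the number essentially unchanged. The move to compound 4, `C=CCn1c(=O)/c(=C\c2cccc(Cl)c2Cl)[nH]c(=O)/c1=C\c1ccccc1OC`, is 2,3-dichlorophenyl in place of 2-fluorophenyl on a double-bonded chain carbon bound to an aromatic carbon. Among the compounds with values here, no measured step covers this particular exchange. Compound 2 also carries a 2,3-dichlorophenyl on a double-bonded chain carbon bound to an aromatic carbon, though it differs from compound 4 in another place. What the two values show is that in this assay compound 2 gives 300 nM, far below compounds 1 and 3. Because compound 2 gives 300 nM, the step to compound 4 is expected to be a 7.6-fold lower number from compound 3 to compound 4 (0.88 log units; beyond the scatter), a lowering of the number. The step of a 1.1-fold lower number from compound 1 to compound 3 (0.03 log units; within the scatter), lying within the scatter, tempers that expectation, since an aryl exchange at this place has once done nothing, and the range is accordingly wide. Compound 4 is therefore estimated at 2500 nM, with a range from 400 nM to 15000 nM.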

Compound 4, half-maximal inhibitory concentration: 2200 nM
The estimate for compound 4 lay 1.1-fold (0.06 log units) above the measured number; measured number inside the range.
By their numbers in this assay, from the lowest: compound 2; then compound 4; then compounds 3 and 1 (each within the scatter of the next).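

At the place on a double-bonded chain carbon bound to an aromatic carbon, the choice of aryl group now matters in this assay: the earlier exchange of 3-methylphenyl for 2-fluorophenyl left the number within the scatter, whereas 2,3-dichlorophenyl gives an 8.6-fold lower number from compound 3 to compound 4 (0.93 log units; beyond the scatter) and a 9.3-fold lower number from compound 1 to compound 4 (0.97 log units; beyond the scatter). The 2,3-dichlorophenyl group does not settle the number by itself, since the change of vinyl in place of hydrogen on a saturated chain carbon bound to an aromatic nitrogen gives a 7.3-fold higher number from compound 2 to compound 4 (0.87 log units; beyond the scatter), so a second place on the shared core also moves the number beyond the scatter. No measurement shown here gives a reason for any of these steps.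

The compounds shown leave open whether both chlorine atoms are needed, as a phenyl ring with a single chlorine, or with a bromine or a trifluoromethyl group, would be required to separate them. They also leave open how the number responds on the ring nitrogen to a saturated propyl chain, or to a longer chain ending in an amine, with the 2,3-dichlorophenyl group held in place.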